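The source may hold more compounds than are shown below. What is called first, only, known or untested is meant among the compounds shown, and "the series" means these compounds.

Going by the values given here, in a functional assay on A549 cells (Homo sapiens) for inhibition (a lower number here means a stronger inhibitor, a higher number a weaker inhibitor), compound 1, `CCOC(=O)C1=C(Nc2ccccc2)S/C(=C\C2CCCCC2)C1=O`, gives 18000 nM and compound 2, `CCOC(=O)C1=C(Nc2ccccc2)S/C(=C\c2cc3ncccc3[nH]2)C1=O`, gives 13600 nM, so compound 2 stands within the scatter of the only other measured compound. Compound 3, `CCOC(=O)C1=C(Nc2ccccc2)S/C(=C\c2ccc(F)c(C#N)c2)C1=O`, differs from compound 2 by a group of 9 heavy atoms (7 carbon, 1 nitrogen, 1 fluorine; one six-membered aromatic ring of carbon only) in place of a group of 9 heavy atoms (7 carbon, 2 nitrogen; one five-membered aromatic ring with 1 hetero atom, one six-membered aromatic ring with 1 hetero atom), on a double-bonded chain carbon bound to a double-bonded ring carbon, with the 3-cyano-4-fluorophenyl entering on a double-bonded chain carbon bound to a double-bonded ring carbon. Among the compounds with values here, one measured step bears on this change, as it altered the group at that same place: a 1.3-fold lower number from compound 1 to compound 2 (0.12 log units; within the scatter). Within the data shown here, that exchange of very different groups left the number within the scatter, although no compound with a 3-cyano-4-fluorophenyl has yet been measured to test this. No step beyond the scatter is therefore expected in this assay, and the estimated step is a 1.1-fold lower number from compound 2 to compound 3 (0.05 log units; within the scatter). The expected value for compound 3 is 12000 nM, with an estimated range of 4000 nM to 36000 nM.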

Compound 3, half-maximal inhibitory concentration: 8000 nM
Compound 3: middle estimate off by 1.5-fold (0.18 log units), on the high side; low and high end bracket the measured number.
By their numbers in this assay, from the lowest: compounds 3, 2 and 1 (each within the scatter of the next, the first and the last beyond it).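

In this assay, going by these compounds alone, the exchange of cyclohexyl for 3-cyano-4-fluorophenyl gives a 2.3-fold lower number from compound 1 to compound 3 (0.35 log units; beyond the scatter), the first step at this place on a double-bonded chain carbon bound to a double-bonded ring carbon to pass beyond the scatter, though only modestly. Exchanging the group of compound 2 for the same 3-cyano-4-fluorophenyl gives a 1.7-fold lower number from compound 2 to compound 3 (0.23 log units; within the scatter), so a group with a single carbon-only aromatic ring and no hydrogen-bond donor stands level with the two-ring group that carries one. Nothing shown accounts for either step. On these data alone, it remains open what a plain phenyl, or a phenyl carrying only the nitrile or only the fluorine, would give at this place. Also open, as far as these compounds go, is how an amine or a carboxylic acid on that ring would read.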